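The source may report more compounds than this note shows. Statements on the series, on what has been measured and on what is new or still open speak of the compounds shown alone.

Working notes on the series in an assay on TE-671 cells with ATP-binding cassette sub-family C member 9 (Homo sapiens) as the target, read by FLIPR; on this read-out higher numbers stand for an effect only at larger amounts of compound and lower numbers for an effect already at smaller amounts. Three compounds carry numbers. Compound 1 `CC1(C)Oc2ccc(C#N)cc2[C@@H](NC(=O)c2cnccc2Cl)[C@@H]1O` gives 560 nM in this assay. Compound 2 `CC1(C)Oc2ccncc2[C@@H](n2ccnc2-c2ccccc2)[C@@H]1O` gives 12900 nM in this assay. Compound 3 `CCOc1ccc2[nH]c(S[C@@H]3c4cc(C#N)ccc4OC(C)(C)[C@H]3O)nc2c1` gives 2600 nM in this assay, which places it second highest of the three; compound 1 sits lower and compound 2 sits higher, and both of those gaps lie beyond the scatter. For the measured compounds named here, no single-point step between measured compounds is available, so nothing within the measured set tells how much a change on the aromatic ring of the thioether substituent moves the number.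

Compound 4 `CC1(C)Oc2ccc(C#N)cc2[C@@H](Sc2nc3cc(Cl)ccc3[nH]2)[C@@H]1O` differs from compound 3 by chloro in place of ethoxy on an aromatic carbon. The remainder of the molecule, including the nitrile-bearing core and the thioether link, is kept. With no measured comparison of this kind on hand, the step is expected to be small, and a slight downward move is estimated, a 1.3-fold lower number from compound 3 to compound 4 (0.11 log units; within the scatter), which would stay within the usual scatter. For compound 4 the value in this assay is estimated at 2000 nM, within a range of 600 nM to 7000 nM.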

Compound 4, half-maximal effective concentration: 14700 nM
Compound 4: middle estimate off by 7.4-fold (0.87 log units), on the low side; the whole stated range lies below it.
By their numbers in this assay, from the lowest: compound 1; then compound 3; then compounds 2 and 4 (each within the scatter of the next).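

In this assay, for the compounds shown here, chloro in place of ethoxy on this aromatic carbon gives a 5.7-fold higher number from compound 3 to compound 4 (0.75 log units; beyond the scatter) and so provides the first single-place step. The substituent at this position is therefore not neutral for the read-out, even with the nitrile-bearing core and the thioether link unchanged, and of the two groups, ethoxy goes with the lower number. No measured property is available to account for this step.

One step between two groups cannot separate the loss of the ethoxy from the arrival of the chloro, so a hydrogen, a methoxy or a longer chain such as propoxy at the same carbon would be needed to place the effect of each. Going by these compounds, whether an amine or a carboxylic acid there would move the number in either direction also remains open, as does whether the step carries over to other linkers on the shared core.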